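This account rests on a few compounds, and the source may have more. Where it says the series, first, only, none or still open, it means among the compounds named here.

Values in a functional assay on HeLa cells (Homo sapiens) for cytotoxicity, in the presence of a further agent that is not named here; on this read-out lower numbers stand for stronger inhibition and higher numbers for weaker inhibition:
- compound 1 `Clc1ccc(-c2cc(-c3ccco3)nc(-c3cccs3)c2)o1`: 18800 nM
- compound 2 `Cc1ccccc1-c1cc(-c2ccc(Cl)o2)cc(-c2ccsc2)n1`: 9770 nM
- compound 3 `Clc1cccc(-c2cc(-c3ccc(Cl)o3)cc(-c3cccs3)n2)c1`: 12800 nM

Compound 2 lies within the scatter of both compound 1 and compound 3, so these three values do not separate. Compound 4 `Cc1ccc(-c2cc(-c3ccc(Cl)o3)cc(-c3ccsc3)n2)cc1` is still unmeasured. The change is 4-methylphenyl in place of 2-methylphenyl on an aromatic carbon, next to the ring nitrogen. Among the measured compounds shown here, no measured step moves a methyl group. For the measured compounds named here, the only measured step at a group in that place is a 1.5-fold lower number from compound 1 to compound 3 (0.17 log units; within the scatter), which offers indirect guidance at best. No step beyond the scatter is therefore expected in this assay.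

The expected step is small: a 1.1-fold higher number from compound 2 to compound 4 (0.05 log units; within the scatter).

For compound 4 the estimate is 11000 nM, with an expected range of 6000 nM to 20000 nM.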

Compound 4, half-maximal inhibitory concentration: 16200 nM
Compound 4: the middle estimate sits 1.5-fold (0.17 log units) below what was measured, within the range that was stated.
By their numbers in this assay, from the lowest: compounds 2, 3, 4 and 1 (each within the scatter of the next).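

Placing the methyl group differently on the phenyl ring at this position, next to the ring nitrogen, gives a 1.7-fold higher number from compound 2 to compound 4 (0.22 log units; within the scatter) in this assay. Among the compounds shown here, this is the first measured change of methyl placement here, and it does not separate 2-methylphenyl from 4-methylphenyl. Nothing measured on these compounds bears on the reason for this step.

As far as these compounds go, whether a group of another kind at this position, such as an amine or a carboxylic acid, would give a step beyond the scatter remains open. The compounds shown also leave open how a longer chain on the phenyl ring would read out.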